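From tert-butoxy to a silicon-bearing group on the shared core

The compounds below may be only part of what the source reports. "The series", "measured", "known", "first", "only" and "open" are said of these compounds alone.

Measured in a functional assay on the whole organism with Rattus norvegicus as the target; a lower number here means that less compound is needed, a higher number that more compound is needed for the effect:
Compound 1 `Nc1nc2ccc(I)cc2s1`: > 10 mg/kg
Compound 2 `CC(C)(C)Oc1ccc2nc(N)sc2c1`: > 10 mg/kg

Compound 2 stands at > 10 mg/kg, which is a limit of this assay and not a number. Compound 1 gives > 10 mg/kg, also a limit. Within the data shown here, the series so far therefore offers only (the limit of > 10 mg/kg in this assay, at which 2 of the 2 values shown sit).

Not yet measured is compound 3 `C[Si](C)(C)c1ccc2nc(N)sc2c1`. The change leading to it is a group of 4 heavy atoms (3 carbon, 1 silicon; no ring) in place of a group of 5 heavy atoms (4 carbon, 1 oxygen; no ring), on an aromatic carbon, on the same aromatic carbon of the shared core that carries tert-butoxy in compound 2.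

Among the measured compounds shown here, only one measured step bears on this: a step that the two limits leave unreadable from compound 1 to compound 2. It also replaces the group at this aromatic carbon, but its size cannot be read, so it fixes neither a size nor a direction for the next step. A report as a limit is expected to be somewhat more likely than a number. The expected step that the limit leaves unreadable from compound 2 to compound 3 is set against a limit and is only a rough estimate, with its direction left open. For compound 3 the estimated value is 15 mg/kg, with an expected range of 5 mg/kg to 40 mg/kg.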

Compound 3, dose for half-maximal effect: 5 mg/kg
Estimate against measurement, compound 3: 3.0-fold (0.48 log units) above, and the stated range covers the measured number.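

In this assay compound 3 gives 5 mg/kg, a number at this aromatic carbon of the shared core, and the first in the series. The other values in the series are a single limit of the assay: the limit of > 10 mg/kg in this assay, at which 2 of the 3 values shown sit. The trimethylsilyl-type group, with its 3 carbon atoms and 1 silicon atom, gives an at least 2.0-fold lower number from compound 2 to compound 3 (0.30 log units; that floor lies within the scatter) in place of tert-butoxy and an at least 2.0-fold lower number from compound 1 to compound 3 (0.30 log units; that floor lies within the scatter) in place of iodo, so the group at this carbon can bring the read-out under that limit, although each printed floor lies within the scatter and neither step has a known full size.

The step between compound 1 and compound 2 cannot be read, so the compounds shown give no order between iodo and tert-butoxy, and with only three groups at one aromatic carbon they indicate no trend across groups. Also open, on these data alone, is whether the silicon atom itself matters, which a tert-butyl group at the same carbon would address, and how an amine or a longer chain there would read in this assay.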